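Chloro to nitro: an expected cytotoxicity estimate

A few compounds are considered here, and "the series" means these few. Any claim that something is new, unique, unknown or untested is made for them only; others in the source may bear on it.

Measured so far:
- Compound 1 `CCOC(=O)c1cc(-c2cccc(OCc3cccc(OC)c3)c2)on1` — > 128000 nM
- Compound 2 `CCOC(=O)c1cc(-c2cccc(OCc3ccccc3Cl)c2)on1` — > 128000 nM

Both numbers are limits of the assay rather than measured values. In an ADME assay on Vero cells (Chlorocebus sabaeus) for cytotoxicity, with a stated time of 72 h (on this read-out lower numbers stand for stronger inhibition and higher numbers for weaker inhibition), compound 1 gives only a limit, > 128000 nM. Compound 2 likewise gives only a limit in this assay, > 128000 nM. Among the compounds with values here, the one step between the measured compounds, a step that the two limits leave unreadable from compound 1 to compound 2, therefore cannot be read: both ends sit at the same limit, as stated by the limit of > 128000 nM in this assay, at which 2 of the 2 values shown sit.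

Compound 3 `CCOC(=O)c1cc(-c2cccc(OCc3ccccc3[N+](=O)[O-])c2)on1` differs from compound 2 by nitro in place of chloro on an aromatic carbon. Within the data shown here, no measured step bears on this change in a readable way, since the only step available is hidden by the two limits. No evidence exists here for a shift in either direction, and the working expectation is that compound 3 will also come back at the limit of this assay.

Compound 3 is therefore estimated at 150000 nM, with a range from 60000 nM to 400000 nM. The step this estimate implies, a step that the limit leaves unreadable from compound 2 to compound 3, is expected to be none beyond the scatter.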

Compound 3, half-maximal inhibitory concentration: > 128000 nM
Compound 3 ended at the assay's limit (the forecaster's own chance of this, stated with the estimate: 85%); the middle value does not contradict the limit.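

Within the data shown here, no step among compound 1, compound 2 and compound 3 can be read in this assay, because each of them gives only a limit of the assay and not a number: the limit of > 128000 nM in this assay, at which 3 of the 3 values shown sit. The compounds shown leave open whether exchanging these groups changes the read-out at all, and at what concentration any of the three would inhibit the cells.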